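The source may report more compounds than this note shows. Statements on the series, on what has been measured and on what is new or still open speak of the compounds shown alone.

Compound 3 `COCC#Cc1cn([C@H]2C[C@H](O)[C@@H](CO)O2)c(=O)[nH]c1=O` gives > 200000 nM in an ADME assay on L1210/0 cells (Mus musculus) for cytotoxicity, with a stated time of 48 h (a higher number here means a weaker inhibitor, a lower number a stronger inhibitor), and this is a limit of the assay, not a number. Compound 1 `C=Cc1cn([C@H]2C[C@H](O)[C@@H](CO)O2)c(=O)[nH]c1=O` gives 14200 nM and compound 2 `C=C(Cl)c1cn([C@H]2C[C@H](O)[C@@H](CO)O2)c(=O)[nH]c1=O` gives 1660 nM, a difference of an 8.6-fold lower number from compound 1 to compound 2 (0.93 log units; beyond the scatter). Compound 4 `CC#Cc1cn([C@H]2C[C@H](O)[C@@H](CO)O2)c(=O)[nH]c1=O` has hydrogen in place of methoxy on a saturated chain carbon bound to a triple-bonded carbon. Among the compounds with values here, no measured step makes this exact change. The nearest guides are an at least 14-fold higher number from compound 1 to compound 3 (1.14 log units; beyond the scatter) and an at least 120-fold higher number from compound 2 to compound 3 (2.08 log units; beyond the scatter), both large and both ending at the limit (the limit of > 200000 nM in this assay, at which 1 of the 3 values shown sits). Removing the methoxy may therefore recover much of the activity, so a large move to a lower number is expected, an at least 20-fold lower number from compound 3 to compound 4 (1.30 log units; beyond the scatter). For compound 4 the estimated value is 10000 nM, with an expected range of 1500 nM to 80000 nM.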

Compound 4, half-maximal inhibitory concentration: > 200000 nM
Compound 4 ended at the assay's limit (the forecaster's own chance of this, stated with the estimate: 10%); middle value at least 20-fold (1.30 log units) from the limit.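

In this assay compound 4 gives only a limit, not a number, so losing the methoxy brings back no readable value. On the aromatic carbon, prop-1-yn-1-yl gives an at least 14-fold higher number from compound 1 to compound 4 (1.14 log units; beyond the scatter) and an at least 120-fold higher number from compound 2 to compound 4 (2.08 log units; beyond the scatter), matching the outcome with 3-methoxyprop-1-yn-1-yl. The step between compound 3 and compound 4 cannot be read, since both ends are limits: the limit of > 200000 nM in this assay, at which 2 of the 4 values shown sit.

As far as these compounds go, it remains open whether an amine on the saturated chain carbon, or a longer chain there, would give a readable value. From the compounds shown here alone, how far compound 3 and compound 4 lie past the limit also remains open.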